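Notes on the amino group of the shared core

This account rests on a few compounds, and the source may have more. Where it says the series, first, only, none or still open, it means among the compounds named here.

Values in a functional assay on the whole organism (Abdomen, strain ddY) for inhibition, with Mus musculus as the target, with stated times of 30 min and 20 min (a lower number here means that less compound is needed, a higher number that more compound is needed for the effect), for the measured compounds
- compound 1 `Cn1ncc(O)c(Cl)c1=O` gives > 100 mg/kg and this is a limit of the assay
- compound 2 `CCOc1c(NC)cnn(C)c1=O` gives 55 mg/kg
- compound 3 `CCCNc1cnn(C)c(=O)c1OCC` gives 72 mg/kg

Compound 3 at 72 mg/kg lies within the scatter of compound 2 at 55 mg/kg on these numbers. Compound 4 `CCOc1c(N(C)C)cnn(C)c1=O` carries dimethylamino in place of propylamino on an aromatic carbon and is otherwise the same as compound 3. Going by the values given here, the one measured step on this amino group is a 1.3-fold higher number from compound 2 to compound 3 (0.12 log units; within the scatter) and it stays small. No step beyond the scatter is therefore expected in this assay for this change. Among the compounds with values here, no compound with dimethylamino has a measured value yet, and the range is kept wide. The expected result is a 1.2-fold lower number from compound 3 to compound 4 (0.08 log units; within the scatter) as estimated here. Compound 4 is estimated at 60 mg/kg with an expected range of 28 mg/kg to 125 mg/kg.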

Compound 4, dose for half-maximal effect: 86 mg/kg
For compound 4 the middle estimate is 1.4-fold (0.16 log units) below the measured one, within the range that was stated.
By their numbers in this assay, from the lowest: compounds 2, 3 and 4 (each within the scatter of the next). At a limit, above all of these: compound 1.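

Compound 4 is the only compound shown with no hydrogen-bond donor on the amino group, yet both steps stay within the scatter: a 1.2-fold higher number from compound 3 to compound 4 (0.08 log units; within the scatter), and a 1.6-fold higher number from compound 2 to compound 4 (0.19 log units; within the scatter). Methylamino, propylamino and dimethylamino on this aromatic carbon therefore cannot be told apart on these numbers. Nothing measured here bears on why these amino groups read alike.

Still open, on these data alone, is whether a free amino group, a cyclic amine such as morpholine or a longer chain on the nitrogen would give a step beyond the scatter.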